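The source may report more compounds than this note shows. Statements on the series, on what has been measured and on what is new or still open speak of the compounds shown alone.

In a functional assay on A549 cells (Homo sapiens) for inhibition, read by MTT assay, with a stated time of 48 h (a higher number here means a weaker inhibitor, a lower number a stronger inhibitor), compound 1 `O=C1N/C(=N\Cc2ccc(Cl)cc2)S/C1=C1/CCNC(=O)c2[nH]ccc21` gives > 100000 nM, a limit of the assay. Compound 3 `O=C1N/C(=N\Cc2ccccc2Cl)S/C1=C1/CCNC(=O)c2[nH]ccc21` gives > 100000 nM, also a limit and not a number, so it stands at the limit of > 100000 nM in this assay, at which 2 of the 3 values shown sit. Compound 2 `O=C1N/C(=N\Cc2cccc(Cl)c2)S/C1=C1/CCNC(=O)c2[nH]ccc21` gives 35200 nM. Compound 4 `Cc1ccc(C/N=C2\NC(=O)/C(=C3\CCNC(=O)c4[nH]ccc43)S2)cc1` differs from compound 3 as follows: 4-methylphenyl in place of 2-chlorophenyl on a saturated chain carbon bound to a double-bonded nitrogen. This places 4-methylphenyl in place of 2-chlorophenyl. For the measured compounds named here, the steps that bear on it are an at least 2.8-fold lower number from compound 1 to compound 2 (0.45 log units; beyond the scatter) and an at least 2.8-fold higher number from compound 2 to compound 3 (0.45 log units; beyond the scatter), both at least modest, while a step that the two limits leave unreadable from compound 1 to compound 3 cannot be read. Only the 3-chlorophenyl compound 2 gave a number, and the 4-chlorophenyl compound 1 did not, so little change is expected in this assay. The estimated step is an at least 1.1-fold lower number from compound 3 to compound 4 (0.04 log units; that floor lies within the scatter). For compound 4 the expected value is 90000 nM, with an estimated range of 35000 nM to 200000 nM.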

Compound 4, half-maximal inhibitory concentration: 9080 nM
The estimate for compound 4 lay 9.9-fold (1.00 log units) above the measured number; the measured number lies below the stated range.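

In this assay, the step of an at least 11-fold lower number from compound 1 to compound 4 (1.04 log units; beyond the scatter) shows that the group on the ring, and not only its placement, moves the number, as methyl in place of chloro gives a large change. The steps of an at least 11-fold lower number from compound 3 to compound 4 (1.04 log units; beyond the scatter) and a 3.9-fold lower number from compound 2 to compound 4 (0.59 log units; beyond the scatter) make compound 4 the strongest of the four shown, although the steps from compound 1 and compound 3 are read against limits of the assay: the limit of > 100000 nM in this assay, at which 2 of the 4 values shown sit.

On these data alone, whether 3-methylphenyl would go further than 4-methylphenyl stays open. Also open, as far as these compounds go, is whether methoxy or trifluoromethyl in the place of methyl would keep the step.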